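A few compounds are considered here, and "the series" means these few. Any claim that something is new, unique, unknown or untested is made for them only; others in the source may bear on it.

Three members of the series have been tested in a functional assay on HuCC-A1 cells (Homo sapiens) for cytotoxicity, read by MTT assay, with a stated time of 48 h; a higher number here means a weaker inhibitor, a lower number a stronger inhibitor. Compound 1 `COc1cc2c(cc1OC)CN(S(=O)(=O)c1ccc(-n3cc(COc4ccccc4C(C)=O)nn3)cc1)CC2` carries a 2-acetylphenyl group on the oxygen on a saturated carbon; in this assay compound 1 gives > 50 ug/mL, which is a limit of the assay and not a number. Compound 2 `Cc1ccccc1OCc1cn(-c2ccc(S(=O)(=O)N3CCc4ccccc4C3)cc2)nn1` in this assay gives > 50 ug/mL, again a limit. Compound 3 `Cc1ccc(OCc2cn(-c3ccc(S(=O)(=O)N4CCc5ccccc5C4)cc3)nn2)cc1` in this assay gives > 50 ug/mL, also a limit. Among the measured compounds shown here, the only step between measured compounds, a step that the two limits leave unreadable from compound 2 to compound 3, cannot be read because of the limit of > 50 ug/mL in this assay, at which 3 of the 3 values shown sit. Compound 1 thus stands at a limit, and no order among the three measured compounds is known.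

Compound 4 `COc1cc2c(cc1OC)CN(S(=O)(=O)c1ccc(-n3cc(COc4ccc5ccccc5c4)nn3)cc1)CC2` differs from compound 1 by naphthalen-2-yl in place of 2-acetylphenyl on an oxygen on a saturated carbon. For the measured compounds named here, no measured step bears on this change, and none of the three values shown gives a number inside the range of the assay. Compound 4 is therefore expected to sit at the limit again, with a step that the limit leaves unreadable from compound 1 to compound 4 expected to be no larger than the scatter. The estimate for compound 4 in this assay is 60 ug/mL, ranging from 25 ug/mL to 200 ug/mL.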

Compound 4, half-maximal inhibitory concentration: > 50 ug/mL
Compound 4: no number, only a limit; the forecaster's own chance of this, stated with the estimate: 80%; the middle value lies beyond the limit too.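

No new step can be read: compound 1 and compound 4 both stand at a limit and not at a number, which leaves the change between them unreadable: the limit of > 50 ug/mL in this assay, at which 4 of the 4 values shown sit.

The compounds shown leave open whether any group on the oxygen on a saturated carbon gives a number in this assay, and with it any order among the four compounds.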